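This account rests on a few compounds, and the source may have more. Where it says the series, first, only, none or still open, it means among the compounds named here.

Working notes on the series, read in a functional assay on A549 cells (Homo sapiens) for antiproliferative activity, read by sulforhodamine B assay, with a stated time of 48 h; a lower number here means a stronger inhibitor, a higher number a weaker inhibitor. Here compound 1 (`COc1ccc(/C=C/C(=O)c2ccccc2-c2ccc(OC)c(OC)c2)cc1OC`) gives 8500 nM, compound 2 (`COc1ccc(/C=C/C(=O)c2ccccc2-c2ccc(F)cc2)cc1`) gives 140 nM, and compound 3 (`COc1ccc(/C=C/C(=O)c2ccccc2-c2ccc(F)cc2)cc1OC`) gives 440 nM. Compound 3 therefore holds the middle of the three numbers, with a 3.1-fold higher number from compound 2 to compound 3 (0.50 log units; beyond the scatter) on one side and a 19-fold lower number from compound 1 to compound 3 (1.29 log units; beyond the scatter) on the other.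

The next compound to be read is compound 4 (`COc1cc(/C=C/C(=O)c2ccccc2-c2ccc(F)cc2)ccc1O`). Its difference from compound 3 is hydrogen in place of methyl on an oxygen on an aromatic ring, that is, methoxy to hydroxy. Within the data shown here, no measured step makes this exchange, so the evidence is indirect. The closest step is a 3.1-fold higher number from compound 2 to compound 3 (0.50 log units; beyond the scatter), a modest one, which adds a methoxy on an aromatic carbon and shows that a change of this kind can register in this assay. The large step of a 19-fold lower number from compound 1 to compound 3 (1.29 log units; beyond the scatter) concerns the 4-fluorophenyl group, which compound 4 retains, so it says little about this exchange.

A step of modest size at most is expected, leaning towards a higher number, and it may stay within the scatter. The estimated step is a 1.6-fold higher number from compound 3 to compound 4 (0.20 log units; within the scatter). For compound 4 the estimated value is 700 nM, with an expected range of 180 nM to 2500 nM.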

Compound 4, half-maximal inhibitory concentration: 7600 nM
Compound 4: middle estimate off by 11-fold (1.04 log units), on the low side, outside the stated range (above it).
By their numbers in this assay, from the lowest: compound 2; then compound 3; then compounds 4 and 1 (each within the scatter of the next).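

In this assay, hydrogen in place of methyl on an oxygen on an aromatic ring, methoxy to hydroxy, gives a 17-fold higher number from compound 3 to compound 4 (1.24 log units; beyond the scatter), so this single methyl carries a large share of the read-out in the 4-fluorophenyl series. Among these compounds, the earlier steps showed only a modest effect for adding a methoxy on an aromatic carbon, a 3.1-fold higher number from compound 2 to compound 3 (0.50 log units; beyond the scatter), and placed the one large step at the other aryl group, a 19-fold lower number from compound 1 to compound 3 (1.29 log units; beyond the scatter); the new step shows that a second place on these molecules responds on a similarly large scale, and that the smallest possible edit there is enough. Nothing in hand explains why the loss of this methyl has so large an effect.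

The compounds shown leave open whether the oxygen needs its methyl specifically or would accept an ethyl, a longer chain or a difluoromethyl, and whether an amine in place of the hydroxy would behave as the hydroxy does. They also leave open whether the same methoxy to hydroxy exchange at the other methoxy of compound 3 would give a step of similar size.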